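Moving the Methyl Around the Pendant Phenyl Ring

A few compounds are considered here, and "the series" means these few. Any claim that something is new, unique, unknown or untested is made for them only; others in the source may bear on it.

Compound 1 `CCn1nc(C)c2c1CCN(C(C(=O)NC)c1ccccc1)C2CCc1cccc(C)c1` and compound 2 `CCn1nc(C)c2c1CCN([C@@H](C(=O)NC)c1ccccc1)[C@H]2COc1ccc(C)cc1` share the same core and are both measured in a functional assay on CHO cells for antagonist activity at Orexin receptor type 2 (Homo sapiens), read by FLIPR and calcium flux; on this read-out lower numbers stand for stronger inhibition and higher numbers for weaker inhibition. In this assay compound 1 gives 19 nM, and compound 2 gives 19 nM in the same test. Compound 1 therefore stands level with compound 2 at the digits shown, a difference that lies within the usual scatter, so neither can be called the stronger of the two.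

Compound 3 `CCn1nc(C)c2c1CCN(C(C(=O)NC)c1ccccc1)C2CCc1ccc(C)cc1` is not yet measured. Against compound 1 the difference is 4-methylphenyl in place of 3-methylphenyl on a saturated chain carbon, two bonds along the chain from a saturated ring carbon. Among the compounds with values here, no measured pair in this set carries that change, so no step for it can be read from the numbers; the closest information is simply the level of compound 1 itself.

Compound 3 is expected to stay close to compound 1 in this assay, with a step of a 1.3-fold higher number from compound 1 to compound 3 (0.12 log units; within the scatter) that is expected to remain within the scatter. The estimate for compound 3 is 25 nM, with a range from 8 nM to 80 nM.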

Compound 3, half-maximal inhibitory concentration: 6 nM
Beside the measured number, compound 3's estimate is 4.2-fold (0.62 log units) above it, and the stated range ends above it.
By their numbers in this assay, from the lowest: compound 3; then compounds 1 and 2 (each within the scatter of the next).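

Exchanging 3-methylphenyl for 4-methylphenyl on a saturated chain carbon, two bonds along the chain from a saturated ring carbon, gives in this assay a 3.2-fold lower number from compound 1 to compound 3 (0.50 log units; beyond the scatter). Within the data shown here, this position therefore responds to where the methyl sits on the ring, even though the entering and leaving groups hold the same atoms; compound 1 and compound 2 offered no single-place step from which this could be read. Nothing measured here bears on why the move changes the number.

On these data alone, whether a trifluoromethyl group or a chlorine atom in place of that methyl would keep or lose the gain remains open. Also open, as far as these compounds go, is whether the same move from 4-methylphenyl to 3-methylphenyl would give a step of like size on the ether-containing chain of compound 2.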